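The compounds below may be only part of what the source reports. "The series", "measured", "known", "first", "only" and "open" are said of these compounds alone.

Working notes on the salicylanilide series.

Compound 1 `O=C(Nc1cccc(Cl)c1)c1cc(Br)cc(Br)c1O` is the reference point. For the measured compounds named here, in an assay for inhibition of HSP60/HSP10 (Homo sapiens), with a stated time of 60 min (on this read-out higher numbers stand for weaker inhibition and lower numbers for stronger inhibition), compound 1 gives 29000 nM, which is the only number obtained in the set. Compound 2 `O=C(Nc1cccc(Cl)c1)c1cc(Br)cc(Br)c1` reaches only a limit of the assay: in this assay compound 2 gives > 100000 nM. Compound 3 `O=C(Nc1cccc(Cl)c1)c1cccc(Br)c1O` likewise sits at a limit, with compound 3 giving > 100000 nM in this assay. Two of the three results therefore sit at the limit of > 100000 nM in this assay, at which 2 of the 3 values shown sit.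

Both measured steps leave compound 1 and go to a limit. Removing the hydroxy gives an at least 3.4-fold higher number from compound 1 to compound 2 (0.53 log units; beyond the scatter); removing one bromo gives an at least 3.4-fold higher number from compound 1 to compound 3 (0.53 log units; beyond the scatter). Both read as losses beyond the scatter, with only a lower bound on their size.

Compound 4 `O=C(Nc1cccc(Cl)c1)c1cc(Br)ccc1O` is the untested analogue. It differs from compound 1 by hydrogen in place of bromo on an aromatic carbon, that is, the remaining bromo, the one ortho to the hydroxy group, is removed while the other bromo stays. Going by the values given here, the closest precedent is the step from compound 1 to compound 3, where loss of a bromo ran past the limit. A loss of similar size is expected here, so the step from compound 1 to compound 4 is estimated at a 3.4-fold higher number from compound 1 to compound 4 (0.54 log units; beyond the scatter). For compound 4 the expected value in this assay is 100000 nM, with a range of 40000 nM to 300000 nM, and a limit result is the likelier outcome.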

Compound 4, half-maximal inhibitory concentration: > 100000 nM
Compound 4: no number, only a limit; the forecaster's own chance of this, stated with the estimate: 60%; the middle value sits exactly at the limit.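

With compound 4, the bromo ortho to a hydroxy group is shown to count as well: in this assay, its replacement by hydrogen gives an at least 3.4-fold higher number from compound 1 to compound 4 (0.53 log units; beyond the scatter). Until now only the loss of the other bromo had been seen, as an at least 3.4-fold higher number from compound 1 to compound 3 (0.53 log units; beyond the scatter), so each bromo of compound 1 has now been replaced singly, and in both cases the result is a limit and not a number. For the compounds shown here, both steps are lower bounds, so they cannot say which bromo contributes more, and the only measured number remains that of compound 1, with the rest of the comparison resting on one ceiling: the limit of > 100000 nM in this assay, at which 3 of the 4 values shown sit.

From the compounds shown here alone, what stays open is whether the bromo ortho to a hydroxy group must be a bromo at all, or whether a methyl, a methoxy or a trifluoromethyl group in that place would keep a measurable number. Equally open is whether an amine or a methoxy group could stand in for the hydroxy group of compound 1, since hydrogen is the only replacement shown there.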